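Series notes: 4-chlorophenyl for thiophen-3-yl, compound 3 to compound 4

The source may hold more compounds than are shown below. What is called first, only, known or untested is meant among the compounds shown, and "the series" means these compounds.

Going by the values given here, compound 3 `CC(C)C[C@H](N)CN(C(=O)[C@@H]1C[C@H]1c1ccccc1)c1ccc(-c2ccsc2)cc1` gives 1200 nM in a functional assay for agonist activity at G protein-coupled receptor 88 (Homo sapiens), read by HTRF and cAMP accumulation (a higher number here means that more compound is needed for the effect, a lower number that less compound is needed), the highest of the two numbers known. Compound 1 `CC(C)(N)CN(C(=O)[C@@H]1C[C@H]1c1ccccc1)c1ccc(-c2ccccc2)cc1` gives 1.4 nM in this assay, a gap to compound 3 that lies well beyond the scatter; compound 1 differs from compound 3 both in the amine chain and in the ring at the far end of the shared core, so the two values do not separate the two parts. Compound 2 `CC[C@H](C)[C@H](N)CN(C(=O)[C@@H]1C[C@H]1c1ccc(C#N)cc1)c1ccc(-c2ccccc2)cc1` reaches only a limit of this assay, > 25000 nM. Of that compound nothing more is known than the limit (the limit of > 25000 nM in this assay, at which 1 of the 3 values shown sits).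

Compound 4 `CC(C)C[C@H](N)CN(C(=O)[C@@H]1C[C@H]1c1ccccc1)c1ccc(-c2ccc(Cl)cc2)cc1` differs from compound 3 by 4-chlorophenyl in place of thiophen-3-yl on an aromatic carbon. A six-membered aromatic ring of carbon only at this place is what compound 1 also carries, and compound 1 gives 1.4 nM; the amine chain, however, stays as in compound 3. The step from compound 3 to compound 4 is expected to be a moderate move toward lower numbers, a 3.0-fold lower number from compound 3 to compound 4 (0.48 log units; beyond the scatter), beyond the scatter but far short of compound 1. Compound 4 is therefore estimated at 400 nM in this assay. The expected range for compound 4 runs from 60 nM to 3000 nM.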

Compound 4, half-maximal effective concentration: 640 nM
For compound 4 the middle estimate is 1.6-fold (0.20 log units) below the measured one; measured number inside the range.
By their numbers in this assay, from the lowest: compound 1; then compounds 4 and 3 (each within the scatter of the next). At a limit, above all of these: compound 2.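

In this assay, replacing thiophen-3-yl with 4-chlorophenyl gives a 1.9-fold lower number from compound 3 to compound 4 (0.27 log units; within the scatter), so with the amine chain of compound 3 held fixed, this position on an aromatic carbon, para to a large group, does not tell the five-membered aromatic ring with its hetero atom from the chlorine-bearing six-membered aromatic ring of carbon only. A six-membered ring of carbon only at this place does not by itself give compound 4 a value like that of compound 1, 1.4 nM, although those two differ in more than one place and allow no direct comparison. Nothing shown gives a reason for this result.

From the compounds shown here alone, the separate contributions of the chlorine and the ring remain open, and a plain phenyl on the amine chain of compound 3 would divide them. Going by these compounds, the share of the amine chain in the value of compound 1 also remains open.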